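Shortening the Side Chain of the Strongest Compound

A few compounds are considered here, and "the series" means these few. Any claim that something is new, unique, unknown or untested is made for them only; others in the source may bear on it.

Compound 1 `CCC(C(=O)N1CCN(c2cccc(Cl)c2)CC1)N1C(=O)CCC1=O`: 100% in a functional assay on the whole organism (strain Swiss) with Mus musculus as the target, in the maximal electroshock model, with a stated time of 1 h, at a dose of 300 mg/kg by the intraperitoneal route; on this read-out higher numbers stand for a stronger effect at the one dose given and lower numbers for a weaker effect
Compound 2 `CCC(C(=O)N1CCN(c2ccccc2F)CC1)N1C(=O)CCC1=O`: 50% in this assay
Compound 3 `CCC(C(=O)N1CCN(c2ccc(C(F)(F)F)cc2)CC1)N1C(=O)CCC1=O`: 0% in this assay

Compound 1 stands highest of the three; the nearest value, that of compound 2, lies lower by a number 50 percentage points lower from compound 1 to compound 2 (beyond the scatter), and the value of compound 3 lies lowest of all. Compound 4 `CC(C(=O)N1CCN(c2cccc(Cl)c2)CC1)N1C(=O)CCC1=O` differs from compound 1 in one place only: hydrogen in place of methyl on a saturated chain carbon, two bonds along the chain from an amide-type nitrogen in a ring and a carbonyl carbon. Going by the values given here, none of the measured steps touches this place; the only step measured, a number 50 percentage points lower from compound 1 to compound 2 (beyond the scatter), changes the aryl group on the ring nitrogen and so gives no guide to the chain. The expectation therefore rests on compound 1 alone, with wide uncertainty. Compound 4 is estimated at 75%, between 30% and 100%. This is an expected step of a number 25 percentage points lower from compound 1 to compound 4 (beyond the scatter).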

Compound 4, a percentage reported as activity, at one dose (the size of the read-out at that dose, not a potency): 75%
Compound 4: middle estimate and measured number agree at the digits printed; the measured number falls inside the stated range.
By their numbers in this assay, from the lowest: compound 3; then compound 2; then compound 4; then compound 1.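

Going by these compounds alone, the earlier compounds differed only in the aryl group on the ring nitrogen, so this is the first view of the saturated chain carbon. In this assay, going from ethyl to methyl gives a number 25 percentage points lower from compound 1 to compound 4 (beyond the scatter), which shows that the read-out responds to this chain as well as to the aryl group, though the step is smaller than the one printed for the aryl change. Nothing measured here explains this step.

Still open, as far as these compounds go, is how a longer chain such as propyl, or an amine or a carboxylic acid at this carbon, would score.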